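Amide variation on the shared core: furanyl to methylcyclohexyl

This account rests on a few compounds, and the source may have more. Where it says the series, first, only, none or still open, it means among the compounds named here.

Of the compounds shown here, two have numbers so far. Compound 1 `CCOC(=O)c1sc(-c2cccc(NC(=O)c3ccc(C(C)(C)C)cc3)c2)nc1Nc1ccc(N2CCN(C)CC2)cc1` carries 4-(tert-butyl)phenyl on the carbonyl carbon and gives 4.22% in a functional assay on Raji cells (Homo sapiens) for antiproliferative activity, read by CCK-8 assay, with a stated time of 72 h, tested at 40 uM; a lower number here means less inhibition, a higher number more inhibition at the concentration tested (going by the name of the read-out). For the measured compounds named here, compound 2 `CCOC(=O)c1sc(-c2cccc(NC(=O)c3ccco3)c2)nc1Nc1ccc(N2CCN(C)CC2)cc1` carries furan-2-yl at the same place and gives 87.6% in this assay, the higher of the two numbers; the one measured step reads a number 83.4 percentage points higher from compound 1 to compound 2 (beyond the scatter).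

Compound 3 `CCOC(=O)c1sc(-c2cccc(NC(=O)[C@H]3CC[C@H](C)CC3)c2)nc1Nc1ccc(N2CCN(C)CC2)cc1` is not yet measured. It differs from compound 2 in one place: 4-methylcyclohexyl in place of furan-2-yl on a carbonyl carbon. Going by the values given here, the only step that bears on this change is the one from compound 1 to compound 2, which exchanged the group on that same carbonyl carbon and was large, a number 83.4 percentage points higher from compound 1 to compound 2 (beyond the scatter). Among the compounds with values here, whether a six-membered non-aromatic ring of carbon only behaves like the aromatic group it replaces or like the one that compound 1 carried is not settled by these two numbers, so the expectation for compound 3 is a drop from compound 2 of uncertain size, a number 57.6 percentage points lower from compound 2 to compound 3 (beyond the scatter), with a wide range. Compound 3 is therefore estimated at 30% in this assay, between 3% and 70%.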

Compound 3, a percentage reported as inhibition, at one concentration (the size of the read-out at that concentration, not a potency): 26.1%
Compound 3: middle estimate off by 3.9 percentage points, on the high side, and the stated range covers the measured number.
By their numbers in this assay, from the lowest: compound 1; then compound 3; then compound 2.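

In this assay, the group on this carbonyl carbon sets the level of inhibition across more than one kind of ring: a number 61.5 percentage points lower from compound 2 to compound 3 (beyond the scatter) shows that 4-methylcyclohexyl does not keep the level seen with furan-2-yl, while a number 21.9 percentage points higher from compound 1 to compound 3 (beyond the scatter) places it clearly above 4-(tert-butyl)phenyl as well. The three groups therefore give three separate levels, with each step beyond the scatter and furan-2-yl at the high end, although the change from furan-2-yl to 4-methylcyclohexyl alters the ring size, the aromatic character, the ring oxygen and the added methyl in one step, so these cannot be told apart here. Nothing available explains the differences between these groups.

From the compounds shown here alone, it remains open whether the high number of compound 2 depends on the ring oxygen or on the aromatic ring, a question that thiophen-2-yl, unsubstituted phenyl or plain cyclohexyl on the same carbonyl carbon would address. Also open, going by these compounds, are the role of the methyl group and of the two defined stereocentres in 4-methylcyclohexyl, and how these single-concentration numbers relate to potency.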